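Swapping Fluoro for Methoxy on the Benzylamine Arm

The source may report more compounds than this note shows. Statements on the series, on what has been measured and on what is new or still open speak of the compounds shown alone.

Three compounds share one core and differ only in the ring carried on the saturated chain carbon bound to a ring nitrogen. Compound 1 `Nc1cc(N)c2nc(-c3ccccc3)c(NCc3ccc(Cl)c(Cl)c3)nc2c1` gives 17400 nM in a functional assay on NCI/ADR-RES cells (Homo sapiens) for inhibition, read by sulforhodamine B assay, with a stated time of 48 h; a higher number here means a weaker inhibitor of growth, a lower number a stronger inhibitor of growth. Compound 2 `COc1ccc(CNc2nc3cc(N)cc(N)c3nc2-c2ccccc2)cc1OC` gives 17800 nM in this assay. Compound 3 `Nc1cc(N)c2nc(-c3ccccc3)c(NCc3ccc(F)cc3)nc2c1` gives 2450 nM in this assay, the lowest of the three numbers. The change between the first two is a 1.0-fold higher number from compound 1 to compound 2 (0.01 log units; within the scatter). The other two steps are a 7.1-fold lower number from compound 1 to compound 3 (0.85 log units; beyond the scatter) and a 7.3-fold lower number from compound 2 to compound 3 (0.86 log units; beyond the scatter).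

Compound 4 `COc1ccc(CNc2nc3cc(N)cc(N)c3nc2-c2ccccc2)cc1` differs from compound 3 by methoxy in place of fluoro on an aromatic carbon. The step from compound 2 to compound 3 bears on this, as compound 2 carries two methoxy groups on that ring and compound 3 carries one fluoro; compound 4 sits between them with one methoxy. A step upward in this assay is therefore expected, smaller than the step from compound 2 to compound 3. The expected step is a 2.4-fold higher number from compound 3 to compound 4 (0.39 log units; beyond the scatter). Compound 4 is estimated at 6000 nM in this assay, within 2000 nM to 18000 nM.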

Compound 4, concentration for 50% growth inhibition: 22900 nM
Compound 4: the middle estimate sits 3.8-fold (0.58 log units) below what was measured; measured number outside the range, above it.
By their numbers in this assay, from the lowest: compound 3; then compounds 1, 2 and 4 (each within the scatter of the next).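

Fluoro and methoxy at this one spot on the ring are far from interchangeable: the swap alone gives a 9.3-fold higher number from compound 3 to compound 4 (0.97 log units; beyond the scatter) in this assay and accounts for the full distance separating compound 3 from the other compounds. Number of methoxy groups does not register here, since removing the second one gives a 1.3-fold higher number from compound 2 to compound 4 (0.11 log units; within the scatter) while the 4-methoxyphenyl and 3,4-dichlorophenyl arms are also level, with a 1.3-fold higher number from compound 1 to compound 4 (0.12 log units; within the scatter) as the step between them, so only the 4-fluorophenyl arm stands apart. Nothing available explains why this single replacement matters so much.

From the compounds shown here alone, whether fluoro itself is what sets compound 3 apart remains open, as a single chloro, a trifluoromethyl or an amine at this spot could give a low number too. The same holds for an unsubstituted phenyl, which would show how the ring behaves with hydrogen there.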